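A few compounds are considered here, and "the series" means these few. Any claim that something is new, unique, unknown or untested is made for them only; others in the source may bear on it.

Working notes on the bromophenyl series.

Compound 1, `COc1cccc(/C=C2\CCC/C(=C\c3ccccc3Br)C2=O)c1OC`, carries a 2-bromophenyl on a double-bonded chain carbon bound to a double-bonded ring carbon. In a functional assay on A549 cells (Homo sapiens) for cytotoxicity, read by MTT assay, with a stated time of 72 h (a higher number here means a weaker inhibitor, a lower number a stronger inhibitor), compound 1 gives only a limit, > 20000 nM. Compound 2, `COc1cccc(/C=C2\CCC/C(=C\c3cccc(Br)c3)C2=O)c1OC`, differs from compound 1 by one change, (3-bromophenyl in place of 2-bromophenyl on a double-bonded chain carbon bound to a double-bonded ring carbon). In this assay compound 2 likewise returns a limit, > 20000 nM. The step that the two limits leave unreadable from compound 1 to compound 2 therefore cannot be read, since both ends sit on the same limit; the relevant evidence is the limit of > 20000 nM in this assay, at which 3 of the 3 values shown sit.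

Compound 3, `COc1ccc(/C=C2\CCC/C(=C\c3ccccc3Br)C2=O)cc1OC`, has a core that differs from the core of compound 1, and the difference between the two cores is not broken down here. In this assay compound 3 again gives a limit, > 20000 nM. So far every measured member of the series sits at the same limit, (the limit of > 20000 nM in this assay, at which 3 of the 3 values shown sit), and no readable step is available anywhere in the set.

Compound 4, `COc1ccc(/C=C2\CCC/C(=C\c3cccc(Br)c3)C2=O)cc1OC`, is not yet measured. It stands to compound 3 exactly as compound 2 stands to compound 1: the change is 3-bromophenyl in place of 2-bromophenyl on a double-bonded chain carbon bound to a double-bonded ring carbon, at the same place as in the earlier pair, so it is the same change. For this assay the expected step is a step that the limit leaves unreadable from compound 3 to compound 4, essentially flat, resting on the observation that the matching change left compound 2 at the limit > 20000 nM and that compound 3 itself sits at the limit > 20000 nM. Compound 4 is accordingly expected to give about 25000 nM, with a plausible range from 8000 nM to 60000 nM, and most likely only a limit will be reported.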

Compound 4, half-maximal inhibitory concentration: 12800 nM
Compound 4: the middle estimate sits 2.0-fold (0.29 log units) above what was measured; low and high end bracket the measured number.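

Within this assay, the change from 2-bromophenyl to 3-bromophenyl on the core of compound 3 gives an at least 1.5-fold lower number from compound 3 to compound 4 (0.19 log units; that floor lies within the scatter); this size is only a floor, and the floor does not clear the usual scatter, so the pair alone does not establish a real gain. The matching steps on the core of compound 1 cannot be read, as both ends of that pair are limits, so there is no second size to set against the first, and the data show neither that the change carries from one core to the other nor that it fails to. For the compounds shown here, compound 4 is the only member with a number rather than a limit, and the rest of the set gives no readable reference point: the limit of > 20000 nM in this assay, at which 3 of the 4 values shown sit.

The compounds shown leave open how large the step on the core of compound 3 really is, and whether the 3-bromophenyl does anything readable on the core of compound 1. They also leave open what happens on either core when an amine or a carboxylic acid takes the place of the bromine on that phenyl ring.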